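The source may hold more compounds than are shown below. What is called first, only, known or untested is meant among the compounds shown, and "the series" means these compounds.

Compound 2 `CN(C(=O)c1cc(F)cc2cc(-c3ccc(Cl)cc3)oc12)C(C)(C)C(=O)O` is one of three compounds examined in an assay on isolated protein for inhibition of endoplasmic reticulum aminopeptidase 1 (Homo sapiens), with stated times of 15 min and 20 min (a lower number here means a stronger inhibitor, a higher number a weaker inhibitor), and it gives 1970 nM. Compound 1 `O=C(NC1(C(=O)O)CCCCC1)c1cccc2c(Br)c(-c3ccc(Cl)cc3)oc12` gives 151 nM in this assay, and compound 3 `CCC(C)(NC(=O)c1cc(F)cc2cc(-c3ccc(C(F)(F)F)cc3)oc12)C(=O)O` gives 2680 nM. On these three numbers compound 2 stands second highest: its number and that of compound 3 lie within the scatter of each other, so nothing can be said of their order, while compound 1 sits far below both, and that gap is beyond the scatter.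

Compound 4 `C[C@H](NC(=O)c1cc(F)cc2cc(-c3ccc(Cl)cc3)oc12)C(=O)O` has not yet been measured in this assay. It differs from compound 2 in a single place: (1-carboxyethyl)amino in place of (1-carboxy-1-methylethyl)(methyl)amino on a carbonyl carbon. For the measured compounds named here, no step between two measured compounds matches this change, so there is no directly comparable pair to lean on. Compound 1, which also carries an amide with a free hydrogen and a carboxylic acid, sits far lower than compound 2 in this assay, but its other parts differ as well, so it only hints that such an amide can go with a strong number. The step from compound 2 to compound 4 is therefore expected to be modest, towards a lower number, and it may not exceed the scatter, with a 1.6-fold lower number from compound 2 to compound 4 (0.22 log units; within the scatter) as the estimate. For compound 4 the expected result in this assay is 1200 nM, within a range from 300 nM to 5000 nM.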

Compound 4, half-maximal inhibitory concentration: 4440 nM
Estimate against measurement, compound 4: 3.7-fold (0.57 log units) below; low and high end bracket the measured number.
By their numbers in this assay, from the lowest: compound 1; then compounds 2, 3 and 4 (each within the scatter of the next, the first and the last beyond it).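

In this assay, the group on the carbonyl carbon now has its first readable step: (1-carboxyethyl)amino in place of (1-carboxy-1-methylethyl)(methyl)amino gives a 2.3-fold higher number from compound 2 to compound 4 (0.35 log units; beyond the scatter). On this shared core, then, the group with 6 heavy atoms, which carries the amide hydrogen and a defined stereocentre, goes with a weaker inhibitor than the group with 8, so the amide hydrogen does not by itself bring a stronger number at this place. Nothing measured on these compounds accounts for the step.

The change removes the methyl on the nitrogen and a methyl on the carbon bearing the carboxylic acid in a single step, and the compounds shown leave open which removal goes with the higher number, a question that (1-carboxy-1-methylethyl)amino on the same core would separate. Also open, on these data alone, are the opposite configuration at the stereocentre of compound 4, the unbranched (carboxymethyl)amino, and a longer chain between the amide nitrogen and the carboxylic acid.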